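This account rests on a few compounds, and the source may have more. Where it says the series, first, only, none or still open, it means among the compounds named here.

In a functional assay on MV4-11 cells (Homo sapiens) for inhibition, read by resazurin assay, with a stated time of 72 h (on this read-out lower numbers stand for stronger inhibition of growth and higher numbers for weaker inhibition of growth), compound 1 (`O=C1NCCC12CCN(c1c(Cl)cncc1-c1ccoc1)CC2`) gives 750 nM, compound 2 (`Cc1ccc(-c2cncc(Cl)c2N2CCC3(CCNC3=O)CC2)o1`) gives 4950 nM and compound 3 (`Cc1csc(-c2cncc(Cl)c2N2CCC3(CCNC3=O)CC2)c1`) gives 650 nM. Compound 3 stands level with compound 1, since the step of a 1.2-fold lower number from compound 1 to compound 3 (0.06 log units; within the scatter) lies within the scatter. Compound 2 sits apart on the high side, seen both in a 6.6-fold higher number from compound 1 to compound 2 (0.82 log units; beyond the scatter) and in a 7.6-fold lower number from compound 2 to compound 3 (0.88 log units; beyond the scatter).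

Compound 4 (`Cc1ccc(-c2cncc(Cl)c2N2CCC3(CCNC3=O)CC2)s1`) has 5-methylthiophen-2-yl in place of 4-methylthiophen-2-yl on an aromatic carbon. For the measured compounds named here, no measured step isolates this change. The nearest evidence is compound 2, the 5-methylfuran-2-yl member, at 4950 nM. However, a 7.6-fold lower number from compound 2 to compound 3 (0.88 log units; beyond the scatter) combines the change of methyl position with a swap of furan for thiophene, so it sets only a loose upper bound on the size of the step.

A small move toward a higher number is therefore expected, probably within the scatter. The expected step is a 1.5-fold higher number from compound 3 to compound 4 (0.19 log units; within the scatter). In this assay, compound 4 is estimated at 1000 nM, with an expected range of 400 nM to 3000 nM.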

Compound 4, concentration for 50% growth inhibition: 650 nM
Compound 4: the middle estimate sits 1.5-fold (0.19 log units) above what was measured; the measured number falls inside the stated range.
By their numbers in this assay, from the lowest: compounds 3, 4 and 1 (each within the scatter of the next); then compound 2.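

In this assay, moving the methyl around the thiophene changes nothing at this aromatic carbon (no change at the digits printed from compound 3 to compound 4 (within the scatter)), so 4-methylthiophen-2-yl and 5-methylthiophen-2-yl read alike. With the methyl position now held constant, the furan-to-thiophene change can be read alone (a 7.6-fold lower number from compound 2 to compound 4 (0.88 log units; beyond the scatter)), which shows that the high number of compound 2 does not come from the 5-methyl placement as such, since compound 4 carries it too. A furan ring alone does not give that high number either, as the step to the unmethylated furan-3-yl compound stays within the scatter (a 1.2-fold lower number from compound 1 to compound 4 (0.06 log units; within the scatter)).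

Still open, going by these compounds, is how a 4-methylfuran-2-yl group, or a carboxylic acid or aminomethyl group in place of the thiophene methyl, would read at this carbon. No measurement offered here explains any of these steps.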